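A few compounds are considered here, and "the series" means these few. Any claim that something is new, unique, unknown or untested is made for them only; others in the source may bear on it.

Of the compounds shown here, two sharing a core have been measured in an ADME assay on C8166 cells (Homo sapiens) for cytotoxicity, read by MTT assay; a lower number here means that less compound is tolerated, a higher number that more compound is tolerated. Compound 1 (`C[C@@H]1C[C@H](O)[C@@]2(C)C(C=O)=CCC[C@@H]2[C@@]1(C)CC(=O)O`) gives 713000 nM, and compound 2 (`C=C[C@@](C)(O)CC[C@@]1(C)[C@H](C)C[C@H](O)[C@@]2(C)C(C)=CCC[C@H]12`) gives 653000 nM. These two values lie within the usual scatter of each other, so compound 2 stands level with compound 1 and the pair cannot be ranked.

Compound 3 (`CC1=CCC[C@@H]2[C@@](C)(CC(=O)O)[C@H](C)C[C@H](O)[C@@]12C`) has not yet been measured in this assay. It differs from compound 2 in one place, with carboxy in place of 2-hydroxy-2-methylbut-3-en-1-yl on a saturated chain carbon bound to a saturated ring carbon. Among the measured compounds shown here, no measured pair differs in one place, so the data offer no direct precedent for this exchange. For the measured compounds named here, the only guide is the close agreement between compound 1 at 713000 nM and compound 2 at 653000 nM, which is thin evidence from just two compounds.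

On that basis, a 1.1-fold higher number from compound 2 to compound 3 (0.03 log units; within the scatter) is expected to stay within the scatter, with no firm direction. For compound 3 the estimated value is 700000 nM, with an expected range from 300000 nM to 1400000 nM.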

Compound 3, half-maximal cytotoxic concentration: 751000 nM
The estimate for compound 3 lay 1.1-fold (0.03 log units) below the measured number, within the range that was stated.
By their numbers in this assay, from the lowest: compounds 2, 1 and 3 (each within the scatter of the next).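

In this assay, carboxy in place of 2-hydroxy-2-methylbut-3-en-1-yl on a saturated chain carbon bound to a saturated ring carbon comes with a 1.2-fold higher number from compound 2 to compound 3 (0.06 log units; within the scatter), so this single exchange has no effect that can be read, even though the entering group is the smaller of the two by heavy atoms and brings no defined stereocentre. Compound 3 also isolates a second place: methyl in place of formyl on a double-bonded ring carbon comes with a 1.1-fold higher number from compound 1 to compound 3 (0.02 log units; within the scatter), and this exchange likewise cannot be told apart from no change. Before compound 3, no pair differed in one place; now each of the two places has its own direct comparison, and neither step stands out from the scatter.

No other measurement bears on these readings, and nothing here accounts for them. Still open, on these data alone, is whether an amine, a methyl ester or a longer chain ending in carboxy on that saturated chain carbon, or a hydroxymethyl group or a carboxylic acid on the double-bonded ring carbon, would move the number beyond the scatter.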